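The source may hold more compounds than are shown below. What is called first, only, known or untested is meant among the compounds shown, and "the series" means these compounds.

Of the compounds shown here, two have been measured. Compound 1 `O=C(C(Nc1ccccc1)c1ccc(C(F)(F)F)cc1)N1CCC[C@@H]1c1ccccc1Cl` gives 168 nM in an assay on HEK293 cells for antagonist activity at transient receptor potential M8 protein (Canis lupus familiaris), read by fluorescence and calcium flux, with a stated time of 5 min; a higher number here means a weaker inhibitor, a lower number a stronger inhibitor. Going by the values given here, compound 2 `O=C(C(Nc1ccccc1F)c1ccc(C(F)(F)F)cc1)N1CCCC1c1cccc(F)c1` gives 9 nM in this assay, the lowest of the two numbers so far; its gap to compound 1 is beyond the usual scatter, so compound 2 is the stronger inhibitor of the pair.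

Compound 3 `O=C(O)c1cccc(C2CCCN2C(=O)C(Nc2ccccc2F)c2ccc(C(F)(F)F)cc2)c1` has not yet been measured in this assay. It differs from compound 2 in one place: carboxy in place of fluoro on an aromatic carbon. Among the compounds with values here, no measured pair in this set carries that same change, so the size of the step cannot be read from the numbers at hand, and only a cautious expectation is possible. Swapping a single fluorine for a carboxy group is a noticeable change to one end of the molecule, and in the absence of a matched pair a moderate weakening is expected rather than a gain. Compound 3 is therefore expected to give about 50 nM in this assay, with a range from 10 nM to 300 nM. That estimate corresponds to an expected step from compound 2 to compound 3 of a 5.6-fold higher number from compound 2 to compound 3 (0.74 log units; beyond the scatter), a step toward a higher number and likely beyond the scatter.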

Compound 3, half-maximal inhibitory concentration: 40 nM
Beside the measured number, compound 3's estimate is 1.3-fold (0.10 log units) above it; the range from low to high includes it.
By their numbers in this assay, from the lowest: compound 2; then compound 3; then compound 1.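

Going by these compounds alone, this is the first matched pair, and it gives a direct reading of one change at this ring position. In this assay, replacing fluoro with carboxy, so that 3-fluorophenyl becomes 3-carboxyphenyl, gives a 4.4-fold higher number from compound 2 to compound 3 (0.65 log units; beyond the scatter) and this counts as a modest loss of inhibition, not a collapse. The position therefore still permits inhibition with a larger group that brings a hydrogen-bond donor and a hydrogen-bond acceptor where fluoro counted neither, although nothing measured here accounts for the size of this step.

The compounds shown leave open whether a similar step would follow from other groups at this place on the ring, such as a methyl ester, a primary amide, an amine or a hydroxymethyl group. They also leave open whether the same swap of fluoro for carboxy would give a step of similar size at another carbon of this ring, or in a compound that differs elsewhere in the shared core.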